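The source may report more compounds than this note shows. Statements on the series, on what has been measured and on what is new or still open speak of the compounds shown alone.

Of the compounds shown here, three from one series have been measured in an assay on cells for displacement of a labelled ligand from transmembrane domain-containing protein TMIGD3 (Homo sapiens), read by scintillation counting, with a stated time of 120 min; a higher number here means a weaker inhibitor, a lower number a stronger inhibitor. Compound 1 `COc1ccc(C(=O)Nc2nccn3cc(-c4ccccc4)nc23)cc1` gives 162 nM, compound 2 `COc1ccc(-c2cn3ccnc(NC(=O)c4ccccc4)c3n2)cc1` gives 121 nM, and compound 3 `Cc1ccc(C(=O)Nc2nc(-c3ccccc3)cn3cc(-c4ccccc4)nc23)cc1` gives 223 nM. Compound 3 thus holds the highest of the three numbers, yet its gap to compound 1 and its gap to compound 2 both lie within the usual scatter of repeated measurements, so on these numbers the three compounds cannot be told apart in strength. Among the measured compounds shown here, no pair among them differs in only one place, so no single structural step has been measured.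

Compound 4 `O=C(Nc1nc(-c2ccccc2)cn2cc(-c3ccccc3)nc12)c1ccco1` has not yet been tested. It keeps the whole of compound 3 except for one change: furan-2-yl in place of 4-methylphenyl on a carbonyl carbon. For the measured compounds named here, nothing measured so far shows how an exchange of the group on the carbonyl carbon shifts the number in this assay, so the expectation for this step rests on the change alone and is accordingly cautious.

The step from compound 3 to compound 4 is expected to be small, a 1.2-fold lower number from compound 3 to compound 4 (0.09 log units; within the scatter), and not clearly beyond the scatter in either direction. Compound 4 is therefore estimated at 180 nM in this assay, with a likely range from 60 nM to 550 nM.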

Compound 4, inhibition constant: 67 nM
Estimate against measurement, compound 4: 2.7-fold (0.43 log units) above, and the stated range covers the measured number.
By their numbers in this assay, from the lowest: compounds 4, 2, 1 and 3 (each within the scatter of the next, the first and the last beyond it).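

In this assay the group on the carbonyl carbon proves able to shift the number, with a 3.3-fold lower number from compound 3 to compound 4 (0.52 log units; beyond the scatter) as furan-2-yl replaces 4-methylphenyl. Among the compounds shown here, this is the only step that differs in one place, and although modest in size, it lies beyond the scatter, so an exchange of one aromatic ring for another at this position, with the rest of compound 3 unchanged, can be read in this assay. The exchange alters ring size, heavy-atom count and hydrogen-bond acceptor count together, and no measurement at hand separates these differences or accounts for the lower number.

As far as these compounds go, it remains open whether the furan oxygen or the smaller ring matters more, a question that plain phenyl, thiophen-2-yl or furan-3-yl on the same carbonyl carbon could help to settle. Also open, from the compounds shown here alone, are how a non-aromatic group such as cyclohexyl or an aminomethyl group would fare at this position, and whether furan-2-yl would shift the number in the same way on the cores of compound 1 and compound 2.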